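Succinimide in place of piperidine on the oxazolidinone chain

The compounds below may be only part of what the source reports. "The series", "measured", "known", "first", "only" and "open" are said of these compounds alone.

Compound 1 `CN(CCC#N)C[C@H]1CN(c2ccc(-n3cc(-c4ccccn4)cn3)c(F)c2)C(=O)O1` was examined in an ADME assay on L02 cells (Homo sapiens) for cytotoxicity, read by MTT assay, with a stated time of 48 h; a higher number here means a weaker inhibitor, a lower number a stronger inhibitor. In this assay compound 1 reaches only the limit > 400 ug/mL, which is a limit of the assay and not a number. Compound 2 `O=C1O[C@@H](CN2CCCCC2)CN1c1ccc(-n2cc(-c3ccccn3)cn2)c(F)c1` differs from it in one place. In this assay compound 2 likewise gives > 400 ug/mL, again a limit rather than a measured number. The step that the two limits leave unreadable from compound 1 to compound 2 is therefore unreadable, since (the limit of > 400 ug/mL in this assay, at which 2 of the 2 values shown sit). Compound 2 thus stands at the limit of this assay, with no measured number to place it. Compound 3 `O=C1CCC(=O)N1C[C@H]1CN(c2ccc(-n3cc(-c4ccccn4)cn3)c(F)c2)C(=O)O1` is the next change: 2,5-dioxopyrrolidin-1-yl in place of piperidin-1-yl on a saturated chain carbon bound to a saturated ring carbon. Within the data shown here, no measured step bears readably on this change, so the account offers no measured size to lean on. The step of a number no higher from compound 2 to compound 3 (the limit leaves the size open) is expected to show no shift beyond the scatter. Compound 3 is estimated at 400 ug/mL, with a range from 200 ug/mL to 800 ug/mL.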

Compound 3, half-maximal inhibitory concentration: > 400 ug/mL
Compound 3: only a limit was reported (the forecaster's own chance of this, stated with the estimate: 80%); the middle value sits exactly at the limit.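

The steps linking compound 3 to compound 1 and compound 2 cannot be read in this assay, as all three compounds end at a limit of the assay and not at a number: the limit of > 400 ug/mL in this assay, at which 3 of the 3 values shown sit.

The compounds shown leave open whether these three side chains on the shared core differ at all in this assay.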